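The compounds below may be only part of what the source reports. "The series", "measured", "known", "first", "only" and "open" are said of these compounds alone.

Compound 1 `O=[N+]([O-])c1cn2c(n1)OC[C@@H](OCc1ccc(-c3ccc(F)cc3)s1)C2` was examined in an ADME assay on Vero cells (Chlorocebus sabaeus) for cytotoxicity, with a stated time of 72 h; on this read-out higher numbers stand for weaker inhibition and lower numbers for stronger inhibition. In this assay compound 1 gives only a limit, > 128000 nM. Compound 2 `COc1ccc(-c2ccc(CO[C@@H]3COc4nc([N+](=O)[O-])cn4C3)s2)cc1F` differs from compound 1 by 3-fluoro-4-methoxyphenyl in place of 4-fluorophenyl on an aromatic carbon. In this assay compound 2 also returns only a limit, > 128000 nM. The step that the two limits leave unreadable from compound 1 to compound 2 is therefore not readable, since both values rest at the limit (the limit of > 128000 nM in this assay, at which 3 of the 3 values shown sit). Compound 3 `O=[N+]([O-])c1cn2c(n1)OC[C@@H](OCc1csc(-c3ccc(F)cc3)n1)C2` has a different core from compound 1, and the difference between the two cores is not broken down here. In this assay compound 3 again yields only a limit, > 128000 nM. Compound 4 `COc1ccc(-c2nc(CO[C@@H]3COc4nc([N+](=O)[O-])cn4C3)cs2)cc1F` stands to compound 3 as compound 2 stands to compound 1, with 3-fluoro-4-methoxyphenyl in place of 4-fluorophenyl on an aromatic carbon; the surroundings differ, the ring here being a five-membered aromatic ring with 1 nitrogen and 1 sulfur and the position next to the ring nitrogen as well as next to the ring sulfur, so this counts as the same kind of change, not the same change. Because all three measured values sit at the limit (the limit of > 128000 nM in this assay, at which 3 of the 3 values shown sit), the step is expected to be a step that the limit leaves unreadable from compound 3 to compound 4, beside the unreadable a step that the two limits leave unreadable from compound 1 to compound 2. Compound 4 is accordingly expected to give about 200000 nM in this assay, most likely once more as a limit, within a range from 100000 nM to 600000 nM.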

Compound 4, half-maximal inhibitory concentration: > 128000 nM
Compound 4: no number, only a limit (the forecaster's own chance of this, stated with the estimate: 90%); the middle value does not contradict the limit.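

In this assay compound 4 again gives only a limit, > 128000 nM, so the step from compound 3 to compound 4, like that from compound 1 to compound 2, cannot be read. The compounds shown leave open whether 3-fluoro-4-methoxyphenyl in place of 4-fluorophenyl, or the difference between the two cores, alters this read-out at all: the limit of > 128000 nM in this assay, at which 4 of the 4 values shown sit.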